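Adding a Methoxy Group to Compound 2

A few compounds are considered here, and "the series" means these few. Any claim that something is new, unique, unknown or untested is made for them only; others in the source may bear on it.

In a functional assay on DU-145 cells (Homo sapiens) for cytotoxicity, read by MTT assay, with a stated time of 48 h (a lower number here means a stronger inhibitor, a higher number a weaker inhibitor), compound 2 `COc1ccc(/C=C/C(=O)/C=C/c2cc3ccccc3nc2Oc2cccc(Cl)c2)cc1OC` gives > 10000 nM, which is a limit of the assay and not a number. Compound 1 `COc1cc(OC)c(OC)cc1/C=C/C(=O)/C=C/c1cc2ccccc2nc1Cl`, which carries a 2,4,5-trimethoxyphenyl group, gives 3990 nM. Compound 3 `COc1cc(OC)c(OC)cc1/C=C/C(=O)/C=C/c1cc2ccccc2nc1Oc1cccc(Cl)c1` takes compound 2 from 3,4-dimethoxyphenyl to 2,4,5-trimethoxyphenyl, with methoxy in place of hydrogen on an aromatic carbon. For the measured compounds named here, no measured pair isolates this change, so only a modest shift towards stronger inhibition is expected in this assay, and the reading may again be a limit. The expected size is a small step of an at least 1.2-fold lower number from compound 2 to compound 3 (0.09 log units; that floor lies within the scatter). For compound 3 the estimated value is 8000 nM, within a range of 3000 nM to 20000 nM.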

Compound 3, half-maximal inhibitory concentration: > 10000 nM
Compound 3: a limit, no number; the forecaster's own chance of this, stated with the estimate: 45%; middle value at least 1.2-fold (0.09 log units) away from the limit.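

In this assay compound 3 gives > 10000 nM as a limit and not a number. The step from compound 2 to compound 3 cannot be read, so the added methoxy shows no measurable gain, because both values are limits: the limit of > 10000 nM in this assay, at which 2 of the 3 values shown sit. With 2,4,5-trimethoxyphenyl held fixed, 3-chlorophenoxy in place of chloro gives an at least 2.5-fold higher number from compound 1 to compound 3 (0.39 log units; beyond the scatter) in a clear move towards weaker inhibition.

From the compounds shown here alone, what the methoxy does while chloro stays in place remains open. So does whether an amine in place of 3-chlorophenoxy would return a readable number.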